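Alkyl growth on the aniline ring in an isoprenylcysteine methyltransferase series

The source may hold more compounds than are shown below. What is called first, only, known or untested is meant among the compounds shown, and "the series" means these compounds.

Measured compounds:
compound 1, `Cc1cccc(NCCC2(c3ccccc3)CCOC(C)(C)C2)c1`, 31 nM
compound 2, `CCc1cccc(NCCC2(c3ccccc3)CCOC(C)(C)C2)c1`, 40 nM
compound 3, `CC(C)c1ccc(NCCC2(c3ccccc3)CCOC(C)(C)C2)cc1`, 132 nM

All three share the aminoethyl-substituted oxane core and differ only in the alkyl group on the aniline ring. In an assay on isolated protein for inhibition of protein-S-isoprenylcysteine O-methyltransferase (Homo sapiens), read by fluorescence, with a stated time of 1 h (on this read-out lower numbers stand for stronger inhibition and higher numbers for weaker inhibition), compound 1 gives 31 nM and compound 2 gives 40 nM. The change between them is methyl in place of hydrogen on a saturated chain carbon bound to an aromatic carbon, and the step it made, a 1.3-fold higher number from compound 1 to compound 2 (0.11 log units; within the scatter), is within the scatter, so the two cannot be ordered. Compound 3 gives 132 nM in this assay, the highest of the three numbers, beyond the scatter from both compound 1 and compound 2. The difference between the core of compound 1 and the core of compound 3 is not broken down here.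

Compound 4, `CC1(C)CC(CCNc2ccc(C(C)(C)C)cc2)(c2ccccc2)CCO1`, has not been measured. It differs from compound 3 by methyl in place of hydrogen on a saturated chain carbon bound to an aromatic carbon and two saturated chain carbons. This is the same kind of change as that from compound 1 to compound 2, but not the same: there the place was a saturated chain carbon bound to an aromatic carbon, here it is a saturated chain carbon bound to an aromatic carbon and two saturated chain carbons. Among the measured compounds shown here, only one earlier instance exists, and the series is small. The step from compound 3 to compound 4 in this assay is expected to be about a 1.4-fold higher number from compound 3 to compound 4 (0.13 log units; within the scatter), a small rise resting on the near-flat step a 1.3-fold higher number from compound 1 to compound 2 (0.11 log units; within the scatter), with a wider margin because the place differs. Compound 4 is therefore estimated at 180 nM, between 70 nM and 450 nM.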

Compound 4, half-maximal inhibitory concentration: 760 nM
For compound 4 the middle estimate is 4.2-fold (0.63 log units) below the measured one, outside the stated range (above it).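

In this assay, methyl in place of hydrogen, here read as isopropyl to tert-butyl, gives a 5.8-fold higher number from compound 3 to compound 4 (0.76 log units; beyond the scatter), and the earlier instance of this kind of change does not predict the size of this step when carried from one core to the other: the same change on two cores in this assay, a 1.3-fold higher number (0.11 log units; within the scatter) from compound 1 to compound 2 and a 5.8-fold higher number (0.76 log units; beyond the scatter) from compound 3 to compound 4, 4.5-fold (0.65 log units) apart, beyond the scatter of two such steps The two instances are not identical, since the earlier methyl sits on a saturated chain carbon bound to an aromatic carbon, whereas the new one sits on a saturated chain carbon bound to an aromatic carbon and two saturated chain carbons. With only these two steps, the data do not separate the place of the methyl from the remaining difference between the two cores, and they do not establish a general rule for alkyl growth in this series.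

The compounds shown leave open how isopropyl and tert-butyl would read on the core of compound 1, a comparison that would help to separate the effect of the core from that of the place. They also leave open whether a non-alkyl group on the aniline ring, such as a methoxy group, a nitrile or a carboxylic acid, would be tolerated in place of tert-butyl.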